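This account rests on a few compounds, and the source may have more. Where it says the series, first, only, none or still open, it means among the compounds named here.

Measured compounds:
Compound 1, `COc1ccc(N/C=C\C(=O)c2cn(-c3ccccc3)nc2-c2ccc(F)cc2)cc1`: 4600 nM
Compound 2, `COc1cc(N/C=C\C(=O)c2cn(-c3ccccc3)nc2-c2ccc(F)cc2)cc(OC)c1OC`: 4890 nM
Compound 3, `COc1ccc(N/C=C\C(=O)c2cn(-c3ccccc3)nc2-c2ccc(Cl)cc2)cc1`: 10700 nM

All three were tested in a functional assay on PC-3 cells (Homo sapiens) for antiproliferative activity, read by MTT assay, with a stated time of 48 h; a higher number here means a weaker inhibitor, a lower number a stronger inhibitor. Compound 1 and compound 2 share part of their structure and differ in the rest; the difference between these two cores is not broken down here. In this assay compound 1 gives 4600 nM and compound 2 gives 4890 nM, two values that lie within the usual scatter of each other, so nothing can be said about which is the stronger inhibitor.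

Compound 3 is compound 1 with one change: chloro in place of fluoro on an aromatic carbon. That change produced a 2.3-fold higher number from compound 1 to compound 3 (0.37 log units; beyond the scatter), a modest step that nonetheless lies beyond the scatter.

Compound 4, `COc1cc(N/C=C\C(=O)c2cn(-c3ccccc3)nc2-c2ccc(Cl)cc2)cc(OC)c1OC`, has not yet been measured. It stands to compound 2 as compound 3 stands to compound 1, carrying the change (chloro in place of fluoro on an aromatic carbon), made at the same kind of place. For the measured compounds named here, since the only guide available is the single earlier step, the expectation is that the step from compound 2 to compound 4 will resemble it, roughly a 2.2-fold higher number from compound 2 to compound 4 (0.35 log units; beyond the scatter), because the earlier change gave a 2.3-fold higher number from compound 1 to compound 3 (0.37 log units; beyond the scatter). On that basis compound 4 is estimated to give about 11000 nM in this assay, with a plausible range from 6000 nM to 20000 nM, the width reflecting that this rests on one step only.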

Compound 4, half-maximal inhibitory concentration: 9980 nM
Compound 4: middle estimate off by 1.1-fold (0.04 log units), on the high side, and the stated range covers the measured number.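

Putting chloro in place of fluoro once more gave a 2.0-fold higher number from compound 2 to compound 4 (0.31 log units; beyond the scatter) in this assay, a modest step in the same direction as the earlier one. Set side by side, the two steps cannot be told apart: the same change on two cores in this assay, a 2.3-fold higher number (0.37 log units; beyond the scatter) from compound 1 to compound 3 and a 2.0-fold higher number (0.31 log units; beyond the scatter) from compound 2 to compound 4, 1.1-fold (0.06 log units) apart, within the scatter of two such steps. This shows that the change from 4-fluorophenyl to 4-chlorophenyl carried over between these two cores with much the same size, and that on both cores the chloro compound is the weaker inhibitor in this cell assay; it does not show that the same step would appear on any further core or in any other assay, and two pairs of compounds say nothing about why the number rises.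

The compounds shown leave open how other groups at this same place on the aromatic ring would behave, such as plain hydrogen, bromo, methyl, trifluoromethyl, a nitrile, an amine or a carboxylic acid, and whether any of them would move the number down rather than up. They also leave open whether a change elsewhere in the molecule would alter the size of the step from fluoro to chloro.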